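Swapping an arylamine for piperidine on the shared core

The source may hold more compounds than are shown below. What is called first, only, known or untested is meant among the compounds shown, and "the series" means these compounds.

Among the compounds with values here, compound 2 `COc1ccc(NC2=CC(=O)c3nc4n(c3C2=O)[C@H]2OC[C@@H](O)[C@H]2OC4)cc1` gives the highest of the two numbers so far in a functional assay on MGC-803 cells (Homo sapiens) for inhibition, read by sulforhodamine B assay (a higher number here means a weaker inhibitor, a lower number a stronger inhibitor), at 1680 nM, though its nearest neighbour compound 1 `O=C1C=C(Nc2ccc(I)cc2)C(=O)c2c1nc1n2[C@H]2OC[C@@H](O)[C@H]2OC1`, at 1400 nM, sits within the scatter. Within the data shown here, the only measured step, a 1.2-fold higher number from compound 1 to compound 2 (0.08 log units; within the scatter), changes a group on the outer ring, not the linking amine, so it offers little guidance here. Compound 3 `O=C1C=C(N2CCCCC2)C(=O)c2c1nc1n2[C@H]2OC[C@@H](O)[C@H]2OC1` differs from compound 2 by piperidin-1-yl in place of (4-methoxyphenyl)amino on a double-bonded ring carbon. Among the measured compounds shown here, with no comparable step measured, a modest weakening is expected for compound 3, at 3000 nM with a range of 800 nM to 12000 nM. The expected step is a 1.8-fold higher number from compound 2 to compound 3 (0.25 log units; within the scatter).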

Compound 3, half-maximal inhibitory concentration: > 8000 nM
Compound 3: only a limit was reported; the forecaster's own chance of this, stated with the estimate: 10%; at least 2.6-fold (0.42 log units) between middle value and limit.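

At this position, a double-bonded ring carbon, the change matters more than the outer-ring swap, which stayed within the scatter in this assay: a 1.2-fold higher number from compound 1 to compound 2 (0.08 log units; within the scatter). Putting piperidin-1-yl on this carbon gives an at least 4.7-fold higher number from compound 2 to compound 3 (0.67 log units; beyond the scatter), and against the iodo analogue it gives an at least 5.7-fold higher number from compound 1 to compound 3 (0.75 log units; beyond the scatter). The reading for compound 3 is a limit rather than a number: the limit of > 8000 nM in this assay, at which 1 of the 3 values shown sits. The compounds shown do not separate the loss of the aromatic ring from the loss of the hydrogen-bond donor. A cyclohexylamino group, which has a non-aromatic ring and keeps that donor, would tell these two apart.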